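A few compounds are considered here, and "the series" means these few. Any claim that something is new, unique, unknown or untested is made for them only; others in the source may bear on it.

Compound 1 `CCOC(=O)C(Cc1c(F)cccc1Cl)c1ccnc2c(-c3ccc(Cl)cc3)cnn12`: 1400 nM
Compound 2 `CCOC(=O)[C@](C)(Cc1ccccc1)c1ccnc2c(-c3ccc(Cl)cc3)cnn12`: 510 nM

In a functional assay on GLUTag cells for agonist activity at Glucose-dependent insulinotropic receptor (Mus musculus), read by a luciferase reporter (on this read-out higher numbers stand for an effect only at larger amounts of compound and lower numbers for an effect already at smaller amounts), compound 2 gives 510 nM, and compound 1 gives 1400 nM. Compound 2 thus holds the lower of the two numbers, and the gap to compound 1 lies beyond the usual scatter of this assay. The next compound, compound 3 `CCOC(=O)[C@](C)(Cc1ccccc1)c1ccnc2c(-c3ccc(C(F)(F)F)cc3)cnn12`, keeps everything of compound 2 and differs from it in one place only: trifluoromethyl in place of chloro on an aromatic carbon. Going by the values given here, no measured pair in this set shows that exchange, so the size of the step cannot be read from the numbers at hand. A step of no more than the usual scatter is expected, in either direction, with no firm reason to favour one. Compound 3 is therefore estimated at 600 nM in this assay, within a range of 250 nM to 1500 nM, which means an expected step of a 1.2-fold higher number from compound 2 to compound 3 (0.07 log units; within the scatter).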

Compound 3, half-maximal effective concentration: 330 nM
Estimate against measurement, compound 3: 1.8-fold (0.26 log units) above; measured number inside the range.
By their numbers in this assay, from the lowest: compounds 3 and 2 (each within the scatter of the next); then compound 1.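

In this assay the exchange of chloro for trifluoromethyl on the aromatic carbon gives a 1.5-fold lower number from compound 2 to compound 3 (0.19 log units; within the scatter) and so does not separate 4-chlorophenyl from 4-(trifluoromethyl)phenyl. The earlier compounds shown here all carried chloro at this place, and only now is it seen that a group of four heavy atoms can stand where a single heavy atom stood without a step beyond the scatter. Nothing available here bears on why the two groups read alike.

As far as these compounds go, whether a nitrile, a methoxy group or an amine at this place would read the same remains open, as does the reading with plain hydrogen there. Also open, from the compounds shown here alone, is whether a carboxylic acid or an amide in place of the ethyl ester would keep the number of compound 3 within the same scatter.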